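A few compounds are considered here, and "the series" means these few. Any claim that something is new, unique, unknown or untested is made for them only; others in the source may bear on it.

Working notes on the series. The shared core of compound 1 `Oc1c(-c2nc(C(O)c3ccccc3)n[nH]2)ncc2cccnc12` carries, in compound 2 `Cc1n[nH]c(-c2ncc3cccnc3c2O)n1`, a methyl group on the triazole part, and compound 3 `CNc1ccnc2c(O)c(-c3nc(C)n[nH]3)ncc12` adds a methylamino group to the same skeleton. Among the compounds with values here, in a physicochemical assay for lipophilicity, at pH 7.4 (a lower number here means a more polar compound, a higher number a more lipophilic compound), compound 1 gives "not determined" (no result reported), compound 2 gives 0.73 and compound 3 gives -0.2, which is the lowest number so far, the step of a number 0.93 log units lower from compound 2 to compound 3 (beyond the scatter) lying beyond the scatter. Compound 4 `Cc1n[nH]c(-c2ncc3c(N(C)C)ccnc3c2O)n1` differs from compound 3 by methyl in place of hydrogen on a nitrogen on an aromatic ring. Within the data shown here, no measured step covers a change on the nitrogen itself; the only known step concerns the methylamino group as a whole. A small rise in this assay is expected, a number 0.40 log units higher from compound 3 to compound 4 (beyond the scatter), so that compound 4 is estimated at 0.2 with a range from -0.3 to 0.7.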

Compound 4, distribution coefficient: -0.6
Compound 4: the middle estimate sits 0.80 log units above what was measured, outside the stated range (below it).
By their numbers in this assay, from the lowest: compound 4; then compound 3; then compound 2.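

In this assay, methyl in place of hydrogen on a nitrogen on an aromatic ring gives a number 0.40 log units lower from compound 3 to compound 4 (beyond the scatter), so at this position the number continues in the direction already seen with the methylamino group rather than reversing when one carbon is added. Taken from the unsubstituted parent, dimethylamino in place of hydrogen on an aromatic carbon gives a number 1.33 log units lower from compound 2 to compound 4 (beyond the scatter), compared with a number 0.93 log units lower from compound 2 to compound 3 (beyond the scatter) for methylamino. Nothing available accounts for this fall. As far as these compounds go, whether an ethyl group or a longer chain on this nitrogen continues the trend remains open. So does the outcome for a cyclic amine such as pyrrolidine at this carbon.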